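From methyl to hydroxy on a weak compound

A few compounds are considered here, and "the series" means these few. Any claim that something is new, unique, unknown or untested is made for them only; others in the source may bear on it.

Compound 1 `CC/C=C/C(=O)N(Cc1ccc(OC)c(O)c1)c1cc(OC)c(OC)c(OC)c1`: 72 nM
Compound 2 `C/C=C/C(=O)N(Cc1ccc(OC)c(C)c1)c1cc(OC)c(OC)c(OC)c1`: 32900 nM

In a functional assay on KYSE-450 cells (Homo sapiens) for inhibition, read by MTT assay, with a stated time of 48 h (a higher number here means a weaker inhibitor, a lower number a stronger inhibitor), compound 2 gives 32900 nM and stands highest of the two numbers, far beyond the scatter from compound 1. Compound 3 `C/C=C/C(=O)N(Cc1ccc(OC)c(O)c1)c1cc(OC)c(OC)c(OC)c1` has not yet been measured. It departs from compound 2 in one place hydroxy in place of methyl on an aromatic carbon with hydroxy in place of methyl on an aromatic carbon, so that 4-methoxy-3-methylphenyl becomes 3-hydroxy-4-methoxyphenyl. Going by the values given here, no measured pair shows this change on its own. Compound 1 carries the same 3-hydroxy-4-methoxyphenyl group and gives 72 nM in this assay so a large fall, well beyond the scatter, is expected. The expected step of a 270-fold lower number from compound 2 to compound 3 (2.44 log units; beyond the scatter) is estimated to lead to a much stronger inhibitor. For compound 3 the estimated value is 120 nM with an expected range from 25 nM to 800 nM in this account.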

Compound 3, half-maximal inhibitory concentration: 67 nM
Compound 3: the middle estimate sits 1.8-fold (0.25 log units) above what was measured; the measured number falls inside the stated range.
By their numbers in this assay, from the lowest: compounds 3 and 1 (each within the scatter of the next); then compound 2.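

In this assay, hydroxy in place of methyl on the aromatic carbon ortho to a methoxy group now stands as a single change, with a 490-fold lower number from compound 2 to compound 3 (2.69 log units; beyond the scatter), so on this core the two groups are far from interchangeable at this position. Hydrogen in place of methyl on a saturated chain carbon bound to a double-bonded chain carbon gives a 1.1-fold lower number from compound 1 to compound 3 (0.03 log units; within the scatter), which lies within the scatter, so the 3-hydroxy-4-methoxyphenyl compounds stay level across this chain change. The data shown offer nothing that explains the size of the hydroxy step.

From the compounds shown here alone, it remains open whether an amine or a fluorine at this aromatic position would behave like hydroxy or like methyl. Going by these compounds, it is also open how a longer chain on the double bond would read in this assay.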